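Swapping a Polar Side Chain for a Thioether Tail

This account rests on a few compounds, and the source may have more. Where it says the series, first, only, none or still open, it means among the compounds named here.

Compound 1 `CC(C)c1n[nH]c2c(NCc3ccc(-c4ccccn4)cc3)nc(SC[C@H](O)CN)nc12` is one of three close relatives that share a core and differ only in the chain on a saturated chain carbon bound to a sulfur. In a functional assay on HT cells (Homo sapiens) for antiproliferative activity, read by fluorescence, with a stated time of 72 h (on this read-out lower numbers stand for stronger inhibition of growth and higher numbers for weaker inhibition of growth), compound 1 gives 63 nM. Compound 2 `CC(C)c1n[nH]c2c(NCc3ccc(-c4ccccn4)cc3)nc(SCCO)nc12` gives 48 nM, and compound 3 `CC(=O)NCCSc1nc(NCc2ccc(-c3ccccn3)cc2)c2[nH]nc(C(C)C)c2n1` gives 71 nM. Among these three numbers compound 1 stands second highest, and no two of them are separated by more than the scatter: a 1.3-fold lower number from compound 1 to compound 2 (0.12 log units; within the scatter), a 1.1-fold higher number from compound 1 to compound 3 (0.05 log units; within the scatter), and a 1.5-fold higher number from compound 2 to compound 3 (0.17 log units; within the scatter).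

Compound 4 `CSCCSc1nc(NCc2ccc(-c3ccccn3)cc2)c2[nH]nc(C(C)C)c2n1` has not been measured. It differs from compound 1 in that ((methylsulfanyl)methyl in place of 2-amino-1-hydroxyethyl on a saturated chain carbon bound to a sulfur). For the measured compounds named here, the steps that bear on it are the two that alter the same chain: a 1.3-fold lower number from compound 1 to compound 2 (0.12 log units; within the scatter) and a 1.1-fold higher number from compound 1 to compound 3 (0.05 log units; within the scatter). Both stayed within the scatter, though neither matches the new change exactly, and three compounds are a thin basis. Compound 4 is therefore expected to show a 1.2-fold higher number from compound 1 to compound 4 (0.08 log units; within the scatter), a step of no more than the scatter. Compound 4 is estimated at 75 nM, with a range from 30 nM to 190 nM.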

Compound 4, concentration for 50% growth inhibition: 975 nM
Compound 4: the middle estimate sits 13-fold (1.11 log units) below what was measured, outside the stated range (above it).
By their numbers in this assay, from the lowest: compounds 2, 1 and 3 (each within the scatter of the next); then compound 4.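

Until now the chain on a saturated chain carbon bound to a sulfur seemed free to vary, but in this assay the change to (methylsulfanyl)methyl gives a 15-fold higher number from compound 1 to compound 4 (1.19 log units; beyond the scatter) and a gap of similar kind from the other two chains, with a 14-fold higher number from compound 3 to compound 4 (1.14 log units; beyond the scatter) and a 20-fold higher number from compound 2 to compound 4 (1.31 log units; beyond the scatter) as well. The position is therefore not indifferent to what it carries: the three chains that stay within the scatter of one another all hold a hydroxy or an acetamido group, and the chain ending in methylsulfanyl stands apart from them. Nothing given here explains this loss of activity.

On these data alone, what remains open is whether the sulfur itself matters or the absence of a hydroxy, amine or amide group, which a 2-methoxyethyl chain or a plain butyl chain could help separate. A carboxylic acid at the end of the chain also remains an open case.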